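Adding a Methylpiperazine to an Analogue

The source may report more compounds than this note shows. Statements on the series, on what has been measured and on what is new or still open speak of the compounds shown alone.

Within the data shown here, compound 3 `CC(=O)Nc1nn(C)c2cc(-c3ccccc3)[nH]c(=O)c12` stands at the bottom of the three numbers measured so far: in an assay on isolated protein for inhibition of ribosomal protein S6 kinase alpha-1 (Homo sapiens), read by mobility shift assay, tested at 30 uM (a higher number here means more inhibition at the concentration tested (going by the name of the read-out), a lower number less inhibition), compound 3 gives 4%. Its nearest neighbour is compound 2 `Cn1nc(N)c2c(=O)[nH]c(-c3ccccc3)cc21`, which in this assay gives 8%; the step of a number 4 percentage points lower from compound 2 to compound 3 (within the scatter) lies within the scatter, so the two compounds cannot be told apart on this read-out. Compound 1 `Nc1n[nH]c2cc(-c3cccs3)[nH]c(=O)c12` is the furthest away, giving 35% in this assay, a number beyond the scatter from compound 3.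

Compound 4 `CC(=O)Nc1nn(C)c2cc(-c3ccc(N4CCN(C)CC4)cc3)[nH]c(=O)c12` differs from compound 3 by 4-methylpiperazin-1-yl in place of hydrogen on an aromatic carbon. Among the measured compounds shown here, no measured step bears on this position: the only step in the set, a number 4 percentage points lower from compound 2 to compound 3 (within the scatter), concerns an acetyl in place of hydrogen on a nitrogen on an aromatic ring and is within the scatter, and the jump from compound 1 to compound 3 involves several changes at once. The expectation therefore rests on the low number of compound 3 itself, with nothing in the data pointing to a large move in either direction. The step of a number 4 percentage points higher from compound 3 to compound 4 (within the scatter) is expected to remain within the scatter. Compound 4 is estimated at 8%, with a range from 0% to 25%.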

Compound 4, a percentage reported as inhibition, at one concentration (the size of the read-out at that concentration, not a potency): 16%
Compound 4: the middle estimate sits 8 percentage points below what was measured; low and high end bracket the measured number.
By their numbers in this assay, from the lowest: compounds 3, 2 and 4 (each within the scatter of the next, the first and the last beyond it); then compound 1.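

In this assay, among these compounds, the change reads as a number 12 percentage points higher from compound 3 to compound 4 (beyond the scatter), and this is the first single change in the set to move the read-out beyond the scatter, where the earlier step, a number 4 percentage points lower from compound 2 to compound 3 (within the scatter), did not. It shows that the aromatic carbon para to a large group, on the six-membered aromatic ring of carbon only, accepts 4-methylpiperazin-1-yl without any loss in this read-out, and that this position responds to substitution while the acetyl change on the ring nitrogen gave nothing that could be told apart. No measurement available here says why the number moves at this position.

As far as these compounds go, what remains open is which part of the new group carries the step: a morpholine, a piperidine, an unmethylated piperazine or a simple dimethylamino group on the same carbon would separate the ring from its second nitrogen and its methyl. Also open, from the compounds shown here alone, is whether 4-methylpiperazin-1-yl would give a similar step on compound 2, which keeps the free amine in place of the acetamide.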